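The source may hold more compounds than are shown below. What is called first, only, known or untested is meant among the compounds shown, and "the series" means these compounds.

Measured in an assay for inhibition of MAP kinase-activated protein kinase 2 (Homo sapiens), read by Z'-LYTE, with a stated time of 1 h, tested at 10 uM; a higher number here means more inhibition at the concentration tested (going by the name of the read-out), a lower number less inhibition:

compound 1 `Nc1nc2c(ncn2[C@@H]2O[C@H](COC(=O)c3cc[nH]c3)[C@@H](O)[C@H]2O)c(=O)[nH]1`: 82%
compound 2 `O=C(OC[C@H]1O[C@@H](n2cnc3c(=O)[nH]cnc32)[C@H](O)[C@@H]1O)c1cc[nH]c1`: 89%
compound 3 `Nc1nc2c(ncn2[C@@H]2O[C@H](COC(=O)c3ccc[nH]3)[C@@H](O)[C@H]2O)c(=O)[nH]1`: 88%

Compound 3 holds the second highest of the three numbers in this assay. Its nearest neighbour is compound 2, whose reading and that of compound 3 lie within the scatter of each other; the furthest is compound 1, and that step is a number 6 percentage points higher from compound 1 to compound 3 (within the scatter), also within the scatter. All three compounds therefore sit in one band at the tested concentration, and no ordering among them can be claimed.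

Compound 4 `O=C(OC[C@H]1O[C@@H](n2cnc3c(=O)[nH]cnc32)[C@H](O)[C@@H]1O)c1ccc[nH]1` differs from compound 3 as follows: hydrogen in place of amino on an aromatic carbon. The same change has been measured once in the series, on the other ester: a number 7 percentage points higher from compound 1 to compound 2 (within the scatter). That single precedent is within the scatter, so no step beyond the scatter is expected here either; the expected step is a number 2 percentage points higher from compound 3 to compound 4 (within the scatter). Compound 4 is accordingly estimated at 90% in this assay, with a range from 79% to 98%, which rests on the reading of compound 3 and on the precedent from compound 1 to compound 2 alone.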

Compound 4, a percentage reported as inhibition, at one concentration (the size of the read-out at that concentration, not a potency): 42%
Beside the measured number, compound 4's estimate is 48 percentage points above it; the measured number lies below the stated range.
By their numbers in this assay, from the lowest: compound 4; then compounds 1, 3 and 2 (each within the scatter of the next).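

Removing the amino group from the aromatic carbon between two ring nitrogen atoms is not a neutral change on every ester: with the 1H-pyrrol-2-yl ester it gives a number 46 percentage points lower from compound 3 to compound 4 (beyond the scatter), so its effect in this assay depends on the ester: the same change on two cores in this assay, a number 7 percentage points higher (within the scatter) from compound 1 to compound 2 and a number 46 percentage points lower (beyond the scatter) from compound 3 to compound 4, 53 percentage points apart, beyond the scatter of two such steps. The move from 1H-pyrrol-3-yl to 1H-pyrrol-2-yl likewise depends on the core, and without the amino group it gives a number 47 percentage points lower from compound 2 to compound 4 (beyond the scatter): the same change on two cores in this assay, a number 6 percentage points higher (within the scatter) from compound 1 to compound 3 and a number 47 percentage points lower (beyond the scatter) from compound 2 to compound 4, 53 percentage points apart, beyond the scatter of two such steps. Either the amino group or the 1H-pyrrol-3-yl ester is present in compounds 1, 2 and 3, which share one band, while compound 4 has neither and stands apart.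

Going by these compounds, whether a methylamino group or a hydroxyl group on that carbon would keep the reading with the 1H-pyrrol-2-yl ester remains open. Readings at a single concentration also leave open how compounds 1, 2 and 3 compare at other concentrations.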